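The source may hold more compounds than are shown below. What is called first, only, known or untested is meant among the compounds shown, and "the series" means these compounds.

In a functional assay on MDA-MB-231 cells (Homo sapiens) for inhibition, read by MTT assay, with a stated time of 72 h (a higher number here means a weaker inhibitor, a lower number a stronger inhibitor), compound 1 (`Cc1ccc(C(C)C)c(OCc2cn(-c3ccccc3)nn2)c1`) gives 45100 nM, level with compound 2 (`Cc1ccc(C(C)C)c(OCc2cn(-c3cccc(Cl)c3)nn2)c1`) at 45200 nM. Compound 3 (`Cc1ccc(C(C)C)c(OCc2cn(-c3ccc(F)cc3)nn2)c1`) departs from compound 1 by fluoro in place of hydrogen on an aromatic carbon, para to a large group. Within the data shown here, the one measured step that bears on this is chloro in place of hydrogen on an aromatic carbon, a 1.0-fold higher number from compound 1 to compound 2 (0.00 log units; within the scatter). Among the measured compounds shown here, no measured step involves fluoro itself. No step beyond the scatter is therefore expected in this assay. The expected step is a 1.0-fold lower number from compound 1 to compound 3 (0.00 log units; within the scatter). Compound 3 is estimated at 45000 nM, with an expected range of 23000 nM to 85000 nM.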

Compound 3, half-maximal inhibitory concentration: 32600 nM
Beside the measured number, compound 3's estimate is 1.4-fold (0.14 log units) above it; measured number inside the range.
By their numbers in this assay, from the lowest: compounds 3, 1 and 2 (each within the scatter of the next).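

Phenyl to 4-fluorophenyl gives the first reading for a substituent para to a large group in this assay (a 1.4-fold lower number from compound 1 to compound 3 (0.14 log units; within the scatter)). Against the 3-chlorophenyl analogue the picture holds (a 1.4-fold lower number from compound 2 to compound 3 (0.14 log units; within the scatter)), so neither halogen on this ring moves the number beyond the scatter. No measured evidence bears on why these values stay level. As far as these compounds go, whether an amine, a carboxylic acid or a methoxy group at this position would shift the number remains open. The same holds for a longer chain on this ring.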